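The source may hold more compounds than are shown below. What is called first, only, known or untested is meant among the compounds shown, and "the series" means these compounds.

Compound 1 `O=[N+]([O-])c1ccc(CN2CCC(n3cc(CC(OCc4cc(-c5ccc(Br)cc5)no4)c4ccc(Br)cc4)nn3)CC2)cc1` and compound 2 `O=[N+]([O-])c1ccc(CN2CCC(n3cc(CC(OCc4cc(-c5ccccc5F)no4)c4ccc(Br)cc4)nn3)CC2)cc1` share one core and differ only on one aromatic ring. In a functional assay on HCT-116 cells (Homo sapiens) for cytotoxicity, with a stated time of 48 h (a lower number here means a stronger inhibitor, a higher number a weaker inhibitor), compound 1 gives a limit, > 25000 nM, and not a number. Among the compounds with values here, compound 2 gives 9000 nM in this assay, the only number recorded in this set. Within the data shown here, the one measured step, an at least 2.7-fold lower number from compound 1 to compound 2 (0.44 log units; beyond the scatter), concerns the same ring that changes again here. Compound 3 `COc1ccccc1-c1cc(COC(Cc2cn(C3CCN(Cc4ccc([N+](=O)[O-])cc4)CC3)nn2)c2ccc(Br)cc2)on1` differs from compound 2 by methoxy in place of fluoro on an aromatic carbon. Among the measured compounds shown here, no measured step swaps fluoro for methoxy, so the expected step of no change at the digits printed from compound 2 to compound 3 (within the scatter) is kept within the scatter. Compound 3 is therefore estimated at 9000 nM in this assay, with a range from 3000 nM to 25000 nM.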

Compound 3, half-maximal inhibitory concentration: > 25000 nM
Compound 3 ended at the assay's limit (the forecaster's own chance of this, stated with the estimate: 25%); middle value at least 2.7-fold (0.44 log units) from the limit.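

The change from fluoro to methoxy on this aromatic carbon brings an at least 2.7-fold higher number from compound 2 to compound 3 (0.44 log units; beyond the scatter) in this assay. Compound 3 gives a limit, > 25000 nM, and not a number. The earlier step could have suggested that a group in this ortho place is enough for a measurable value, but of the three compounds only compound 2, with its 2-fluorophenyl, gives a number.

The step from compound 1 to compound 3 joins two limits and cannot be read. As far as these compounds go, whether chloro, methyl or hydroxyl on this same aromatic carbon would give a measurable value stays open.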